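The source may report more compounds than this note shows. Statements on the series, on what has been measured and on what is new or still open speak of the compounds shown alone.

Measured compounds:
- compound 1, `COc1cc2nc(N3CCN(C(=O)OCc4ccccc4)CC3)nc(N)c2cc1OC`: 63000 nM
- compound 2, `COc1cc2nc(N3CCN(C(=O)c4cccc5ccccc45)CC3)nc(N)c2cc1OC`: 59000 nM

Going by the values given here, in a functional assay on PC-3 cells (Homo sapiens) for inhibition (on this read-out higher numbers stand for weaker inhibition and lower numbers for stronger inhibition), compound 2 gives the lower of the two numbers, but the only measured step, a 1.1-fold lower number from compound 1 to compound 2 (0.03 log units; within the scatter), is within the scatter, so compound 2 and compound 1 cannot be told apart on this read-out. The next compound, compound 3 `COc1cc2nc(N3CCN(C(=O)c4ccc(C(F)(F)F)cc4)CC3)nc(N)c2cc1OC`, differs from compound 2 by 4-(trifluoromethyl)phenyl in place of naphthalen-1-yl on a carbonyl carbon. Among the compounds with values here, the one step that bears on this change is the exchange of the carbonyl substituent between compound 1 and compound 2, which, as a 1.1-fold lower number from compound 1 to compound 2 (0.03 log units; within the scatter) shows, did not move the number beyond the scatter, even though a benzyloxy group gave way to a naphthalen-1-yl group. Within the data shown here, no measured step speaks to a trifluoromethyl-bearing phenyl group on this carbonyl carbon. On this basis no step beyond the scatter is expected for compound 3, and a 1.0-fold higher number from compound 2 to compound 3 (0.01 log units; within the scatter) is the estimated change. Compound 3 is therefore expected to give about 60000 nM in this assay, with a range from 20000 nM to 180000 nM.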

Compound 3, half-maximal inhibitory concentration: > 100000 nM
Compound 3: a limit, no number (the forecaster's own chance of this, stated with the estimate: 20%); at least 1.6-fold (0.22 log units) between middle value and limit.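

Going by these compounds alone, on the carbonyl carbon, 4-(trifluoromethyl)phenyl is the only one of the three groups that gives no number: compound 3 reads > 100000 nM in this assay, which is a limit of the assay and not a number. The steps that can be read from it are floors, an at least 1.6-fold higher number from compound 2 to compound 3 (0.22 log units; that floor lies within the scatter) and an at least 1.5-fold higher number from compound 1 to compound 3 (0.20 log units; that floor lies within the scatter), so the result does not separate compound 3 from the other two beyond the scatter, although its true value may lie further off than either floor. What the earlier compounds did not show is that this position can carry a group for which the assay returns only its limit, whereas benzyloxy and naphthalen-1-yl both returned numbers that cannot be told apart: the limit of > 100000 nM in this assay, at which 1 of the 3 values shown sits.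

From the compounds shown here alone, how far compound 3 really stands from compound 1 and compound 2 stays open, since a limit gives no size for the gap. Also open, going by these compounds, is whether the limit goes with the trifluoromethyl group or with the single aromatic ring in place of two, which an unsubstituted phenyl group on the same carbonyl carbon, or a phenyl group carrying a methoxy group or a carboxylic acid, would help to separate.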